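Benzothiazole-linked chromones: removing the ring halogen, lengthening the linker

The compounds below may be only part of what the source reports. "The series", "measured", "known", "first", "only" and "open" are said of these compounds alone.

Of the compounds shown here, three sharing one core have been measured. Compound 1 `Cc1ccc2nc(NCCCCOc3cc(O)c4c(=O)cc(-c5ccccc5)oc4c3)sc2c1` gives 6.56 ug/mL in a functional assay on HeLa cells (Homo sapiens) for cytotoxicity, read by sulforhodamine B assay, with a stated time of 48 h; a higher number here means a weaker inhibitor, a lower number a stronger inhibitor. Compound 2 `O=c1cc(-c2ccccc2)oc2cc(OCCCCNc3nc4ccc(I)cc4s3)cc(O)c12` gives 8.12 ug/mL, and compound 3 `O=c1cc(-c2ccccc2)oc2cc(OCCCCNc3nc4ccc(F)cc4s3)cc(O)c12` gives 5.03 ug/mL. The two steps that end at compound 3 are a 1.3-fold lower number from compound 1 to compound 3 (0.12 log units; within the scatter) and a 1.6-fold lower number from compound 2 to compound 3 (0.21 log units; within the scatter); the remaining step is a 1.2-fold higher number from compound 1 to compound 2 (0.09 log units; within the scatter). Compound 3 thus holds the lowest of the three numbers, yet each of its distances to the others sits inside the scatter, so the three values are not distinguished.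

Compound 4 `O=c1cc(-c2ccccc2)oc2cc(OCCCCNNc3nc4ccccc4s3)cc(O)c12` is not yet measured. It differs from compound 3 by (1,3-benzothiazol-2-yl)amino in place of 6-fluoro-1,3-benzothiazol-2-yl on an amine nitrogen; cut one bond further out, the same difference reads (6-fluoro-1,3-benzothiazol-2-yl)amino to ((1,3-benzothiazol-2-yl)amino)amino. Going by the values given here, no measured step covers a change of this kind: the steps to compound 3 swap only a substituent on the aromatic carbon, and all were within the scatter. Compound 4 is therefore expected near compound 3, with a step of a 1.2-fold higher number from compound 3 to compound 4 (0.08 log units; within the scatter) that need not exceed the scatter, and an estimated value of 6 ug/mL, ranging from 3 ug/mL to 12 ug/mL.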

Compound 4, half-maximal inhibitory concentration: 4.64 ug/mL
Beside the measured number, compound 4's estimate is 1.3-fold (0.11 log units) above it; measured number inside the range.
By their numbers in this assay, from the lowest: compounds 4, 3, 1 and 2 (each within the scatter of the next).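

In this assay, (1,3-benzothiazol-2-yl)amino on the amine nitrogen gives a 1.1-fold lower number from compound 3 to compound 4 (0.04 log units; within the scatter), alongside a 1.4-fold lower number from compound 1 to compound 4 (0.15 log units; within the scatter) and a 1.8-fold lower number from compound 2 to compound 4 (0.24 log units; within the scatter). The earlier steps shown here covered only swaps of a substituent on the aromatic carbon; these show that a change to the group on the amine nitrogen also stays inside the scatter, so the four values remain undistinguished. Nothing available bears on why these numbers lie so close.

Each new step joins two changes, the loss of the ring substituent and the added amino nitrogen, and the compounds shown do not separate them. Also open, as far as these compounds go, is whether a carboxylic acid on the 1,3-benzothiazol-2-yl group, or a longer chain to the shared core, would give a step beyond the scatter.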